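Hydroxy for Fluoro on the Pyridine of Compound 1

This account rests on a few compounds, and the source may have more. Where it says the series, first, only, none or still open, it means among the compounds named here.

Compound 1 `O=C(O)Cc1sc(C(c2ccc(F)cc2)c2ccc(F)cc2)nc1-c1ccnc(F)c1` holds the lower of the two numbers measured in an in vitro assay on HEK385-7 cells for displacement of a labelled ligand from prostaglandin D2 receptor 2 (Homo sapiens) (a lower number here means a stronger inhibitor, a higher number a weaker inhibitor), where compound 1 gives 0.48 nM. The other measured compound, compound 2 `O=C(O)Cc1sc(C(c2ccccc2)c2ccc(O)cc2)nc1-c1ccc(F)cc1`, gives 3.4 nM in this assay. Compound 3 `O=C(O)Cc1sc(C(c2ccc(F)cc2)c2ccc(F)cc2)nc1-c1ccnc(O)c1` has not been measured; it differs from compound 1 in one place: hydroxy in place of fluoro on an aromatic carbon. The step to compound 3 is expected to be a 4.2-fold higher number from compound 1 to compound 3 (0.62 log units; beyond the scatter), a moderate weakening somewhat beyond the scatter. Compound 3 is therefore estimated to give about 2 nM in this assay, within a range from 0.5 nM to 8 nM.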

Compound 3, half-maximal inhibitory concentration: 68 nM
Estimate against measurement, compound 3: 34-fold (1.53 log units) below; measured number above the stated range.
By their numbers in this assay, from the lowest: compound 1; then compound 2; then compound 3.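

Placed next to the ring nitrogen, the change from 2-fluoropyridin-4-yl to 2-hydroxypyridin-4-yl gives a 140-fold higher number from compound 1 to compound 3 (2.15 log units; beyond the scatter) in this assay. Within the data shown here, this is the first single-place step, and it shows that this position is far from indifferent to the group it carries, since exchanging one heavy atom costs a large part of the binding strength. No measurement shown here accounts for the size of this step.

Where an amine, a methoxy group or chlorine at this position would fall relative to fluoro and hydroxy remains open. So does whether hydroxy in place of fluoro would cost as much on a ring without the nitrogen.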